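The compounds below may be only part of what the source reports. "The series", "measured", "known", "first", "only" and "open" are said of these compounds alone.

Compound 1 `C=C1[C@H](n2cnc3c(Cl)nc(N)nc32)O[C@H](CO)[C@H]1O`: 176000 nM
Compound 2 `C=C1[C@H](n2cnc3c(O)nc(N)nc32)O[C@H](CO)[C@H]1O`: 150000 nM

Both numbers come from a functional assay on MT4 cells (Homo sapiens) for inhibition; a higher number here means a weaker inhibitor, a lower number a stronger inhibitor. Only these two compounds have been measured so far, and compound 2, at 150000 nM, cannot be told apart from compound 1, since the gap between them lies within the scatter.

The next compound to consider is compound 3 `C=C1[C@H](n2cnc3c(N(C)C)nc(N)nc32)O[C@H](CO)[C@H]1O`. It keeps the shared core of compound 2 and changes one group: dimethylamino in place of hydroxy on an aromatic carbon. In words, dimethylamino stands in place of hydroxy on an aromatic carbon.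

Going by the values given here, one measured step bears on this, as it changes the group on the same carbon: a 1.2-fold lower number from compound 1 to compound 2 (0.07 log units; within the scatter). That swap of chloro for hydroxy left the number within the scatter, so this site has not yet shown any effect in this assay. Among the compounds with values here, still, a single step is thin evidence, and no compound with dimethylamino has been measured. The range must therefore stay wide.

The expected change is a 1.2-fold lower number from compound 2 to compound 3 (0.06 log units; within the scatter), meaning no step beyond the scatter. For compound 3 the estimated value is 130000 nM, with an expected range from 40000 nM to 400000 nM.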

Compound 3, half-maximal inhibitory concentration: > 500000 nM
Compound 3: no number, only a limit (the forecaster's own chance of this, stated with the estimate: 25%); middle value at least 3.8-fold (0.58 log units) away from the limit.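

In this assay, compound 3 gives no number, only a limit of the assay: the limit of > 500000 nM in this assay, at which 1 of the 3 values shown sits.

Until now this aromatic carbon had shown no effect, as the only step there stayed within the scatter: a 1.2-fold lower number from compound 1 to compound 2 (0.07 log units; within the scatter). Dimethylamino now gives the first step beyond the scatter at this position, an at least 3.3-fold higher number from compound 2 to compound 3 (0.52 log units; beyond the scatter), and the comparison with chloro points the same way, an at least 2.8-fold higher number from compound 1 to compound 3 (0.45 log units; beyond the scatter). So the group on this carbon can matter after all, and of the three groups shown, dimethylamino alone stands apart, on the side of weaker inhibition, though the true size of its step stays unknown with only a limit in hand.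

The compounds shown cannot say whether this weaker result goes with the nitrogen on this carbon or with the two methyl groups it carries, and a plain amine or a methylamino group here would separate those two readings. They also leave open whether any group on this carbon could give a clearly lower number than hydroxy or chloro, for example a methoxy group or a small alkyl chain.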